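The source may hold more compounds than are shown below. What is called first, only, known or untested is meant among the compounds shown, and "the series" means these compounds.

Compound 1 `Fc1ccc(C2CC(c3ccc(Cl)s3)=NN2c2nc(-c3ccc(Cl)cc3)cs2)cc1`: 125 ug/mL
Compound 2 `Cc1ccc(-c2csc(N3N=C(c4ccc(C)s4)CC3c3ccc(F)cc3)n2)cc1`: > 500 ug/mL, a limit of the assay rather than a number
Compound 3 `Cc1ccc(C2=NN(c3nc(-c4ccc(F)cc4)cs3)C(c3ccc(F)cc3)C2)s1`: 125 ug/mL

In a functional assay on A549 cells (Homo sapiens) for antiproliferative activity, read by XTT assay, with a stated time of 24 h (on this read-out higher numbers stand for weaker inhibition and lower numbers for stronger inhibition), compound 3 stands level with compound 1, and the two numbers lie within the usual scatter of each other, so no order between them can be claimed. Compound 2 gives only a limit, so its exact position is not known. Among the compounds with values here, the one measured step that changes a single place is an at least 4.0-fold lower number from compound 2 to compound 3 (0.60 log units; beyond the scatter); it rests on (the limit of > 500 ug/mL in this assay, at which 1 of the 3 values shown sits), so its true size could be larger than the bound shows.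

Compound 4 `Cc1ccc(C2=NN(c3nc(-c4ccccc4)cs3)C(c3ccc(F)cc3)C2)s1` differs from compound 3 in the same part of the molecule: hydrogen in place of fluoro on an aromatic carbon. Within the data shown here, no measured pair removes a substituent from that ring altogether, so the only guidance is the fluoro-versus-methyl step, which shows that this position can matter to an at least modest degree. Taking the unsubstituted phenyl as lying somewhere between the two measured cases, the number for compound 4 is expected to stay close to that of compound 3, with a step of a 1.3-fold higher number from compound 3 to compound 4 (0.11 log units; within the scatter) that is estimated to fall within the scatter. Compound 4 is therefore estimated at 160 ug/mL, expected between 70 ug/mL and 400 ug/mL.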

Compound 4, half-maximal inhibitory concentration: > 500 ug/mL
Compound 4: a limit, no number (the forecaster's own chance of this, stated with the estimate: 15%); at least 3.1-fold (0.49 log units) between middle value and limit.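

Compound 3 loses its fluoro in the change from 4-fluorophenyl to phenyl, and in this assay this gives an at least 4.0-fold higher number from compound 3 to compound 4 (0.60 log units; beyond the scatter). The earlier step compared fluoro only with methyl, so it could not show whether methyl was a poor choice at this position or fluoro a good one; hydrogen now behaves like methyl, since compound 2 and compound 4 both end at a limit of the assay while the fluoro compound gives a number. The true size of the new step could be larger than the bound shows, and the step between compound 2 and compound 4 cannot be read, for the same reason: the limit of > 500 ug/mL in this assay, at which 2 of the 4 values shown sit.

Compound 1 also carries a different group on this ring, chloro, but it differs from compound 3 in a second place as well, so it does not settle whether another halogen can do the work of fluoro. From the compounds shown here alone, how an amine, a methoxy group or a carboxylic acid would fare at this position also stays open, and with it whether fluoro is unusual here or simply one of several groups that are tolerated.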